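Swapping the ring nitrogen substituent in compound 3

A few compounds are considered here, and "the series" means these few. Any claim that something is new, unique, unknown or untested is made for them only; others in the source may bear on it.

Measured compounds:
Compound 1 `CC(C)c1onc(-c2c(Cl)cccc2Cl)c1COc1ccc(-c2nc3ccc(C(=O)O)cc3n2CC2CCCCC2)c(F)c1`: 840 nM in an assay on HEK-293T cells for antagonist activity at vitamin D3 receptor (Homo sapiens), read by a luciferase reporter, with a stated time of 24 h; on this read-out lower numbers stand for stronger inhibition and higher numbers for weaker inhibition
Compound 2 `CCCn1c(-c2ccc(OCc3c(-c4c(Cl)cccc4Cl)noc3C(C)C)cc2)nc2ccc(C(=O)O)cc21`: 1400 nM in this assay
Compound 3 `CC(C)c1onc(-c2c(Cl)cccc2Cl)c1COc1ccc(-c2nc3ccc(C(=O)O)cc3n2-c2ccc(F)cc2)cc1`: 2410 nM in this assay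

Among these three numbers compound 3 has the highest, meaning the weakest inhibition. Its nearest neighbour is compound 2, which differs only in the group on the aromatic nitrogen, and that step, a 1.7-fold higher number from compound 2 to compound 3 (0.24 log units; within the scatter), stays within the scatter. Going by the values given here, compound 1 sits further away, and its gap to compound 3 is beyond the scatter, but compound 1 differs in more than one place, so no single step is drawn from it.

Compound 4 `CC(=O)N1CCC(n2c(-c3ccc(OCc4c(-c5c(Cl)cccc5Cl)noc4C(C)C)cc3)nc3ccc(C(=O)O)cc32)CC1` has not yet been measured. It differs from compound 3 in one place: 1-acetylpiperidin-4-yl in place of 4-fluorophenyl on an aromatic nitrogen. Among the compounds with values here, the only measured step at this position is the one from compound 2 to compound 3, and it was small. Within the data shown here, there is no measured step that tells what an acetylpiperidinyl group does here. The expectation is therefore a step of about a 1.2-fold lower number from compound 3 to compound 4 (0.08 log units; within the scatter) in this assay, not beyond the scatter in either direction. Compound 4 is estimated at 2000 nM, with a range from 600 nM to 7000 nM.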

Compound 4, half-maximal inhibitory concentration: > 10000 nM
Compound 4 was reported as a limit; the forecaster's own chance of this, stated with the estimate: 10%; middle value at least 5.0-fold (0.69 log units) from the limit.
By their numbers in this assay, from the lowest: compounds 1, 2 and 3 (each within the scatter of the next, the first and the last beyond it). At a limit, above all of these: compound 4.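

Going by these compounds alone, earlier, the only measured change on this aromatic nitrogen, from propyl to 4-fluorophenyl, stayed within the scatter, so the position could have seemed open to many groups. In this assay, the 1-acetylpiperidin-4-yl group shows otherwise, with an at least 4.1-fold higher number from compound 3 to compound 4 (0.61 log units; beyond the scatter) and an at least 7.1-fold higher number from compound 2 to compound 4 (0.85 log units; beyond the scatter), so at least one group placed here costs inhibition beyond the scatter. The value of compound 4 is a limit of the assay and not a number, so both steps give only a minimum size: the limit of > 10000 nM in this assay, at which 1 of the 4 values shown sits.

From the compounds shown here alone, what stays open is whether the acetyl group or the non-aromatic ring accounts for this loss. A cyclohexyl group or a piperidin-4-yl ring with a free amine on this nitrogen would help separate the two.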